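The compounds below may be only part of what the source reports. "The series", "measured", "known", "first", "only" and "open" are said of these compounds alone.

compound 1 `Cc1ccc(NC(=O)N[C@H](C)c2ccccc2)cc1`: 98%
compound 2 `Cc1ccc(NC(=O)N[C@@H](C)c2ccccc2)cc1`: 99%

Within the data shown here, in an ADME assay on the whole organism with Oryza sativa as the target, tested at 1 uM (on this read-out lower numbers stand for a stronger effect and higher numbers for a weaker effect at the one concentration tested), compound 1 gives 98% and stands within the scatter of compound 2, the only other measured compound, which gives 99%. Among the measured compounds shown here, the single measured step, a number 1 percentage points higher from compound 1 to compound 2 (within the scatter), rests on the fact that compounds 1 and 2 differ only in the configuration as drawn and so concerns configuration only. Compound 3 `CCc1ccc(NC(=O)N[C@H](C)c2ccccc2)cc1` differs from compound 1 by methyl in place of hydrogen on a saturated chain carbon bound to an aromatic carbon. For the measured compounds named here, no measured step covers such an exchange of methyl for hydrogen, so nothing supports a shift beyond the scatter. Compound 3 is expected to give 97%, between 88% and 100%, a step of a number 1 percentage points lower from compound 1 to compound 3 (within the scatter) that is expected to stay within the scatter.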

Compound 3, a percentage reported as activity, at one concentration (the size of the read-out at that concentration, not a potency): 47%
For compound 3 the middle estimate is 50 percentage points above the measured one, and the stated range ends above it.
By their numbers in this assay, from the lowest: compound 3; then compounds 1 and 2 (each within the scatter of the next).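

Among these compounds, on the saturated chain carbon bound to an aromatic carbon, methyl in place of hydrogen (methyl to ethyl, cut one bond further out) is the first change to move the read-out in this assay beyond the scatter: a number 51 percentage points lower from compound 1 to compound 3 (beyond the scatter). This position therefore responds to a change of 1 carbon, whereas the configuration step, a number 1 percentage points higher from compound 1 to compound 2 (within the scatter), stays within the scatter. Nothing available bears on the cause of the new step.

Going by these compounds, whether a longer chain such as propyl, or a hydroxyl group, at this place carries the number further down stays open. So does whether configuration still makes no difference beyond the scatter when ethyl is present.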